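Hydroxamate series: methyl to isopropyl on the chain carbon

This account rests on a few compounds, and the source may have more. Where it says the series, first, only, none or still open, it means among the compounds named here.

Measured so far in a physicochemical assay for solubility; on this read-out lower numbers stand for lower solubility and higher numbers for higher solubility:
compound 1 `O=C(NC1(C(=O)NO)CCS(=O)(=O)CC1)c1ccc(C#Cc2ccccc2)cc1`: 2000 nM
compound 2 `CC(NC(=O)c1ccc(C#Cc2ccccc2)cc1)C(=O)NO`: 29000 nM
compound 3 `O=C(NC1(C(=O)NO)CCOCC1)c1ccc(C#Cc2ccccc2)cc1`: 5000 nM

Compound 2 gives the highest number of the three in this assay. Its nearest neighbour is compound 3, whose number is lower by a gap beyond the scatter; compound 1 lies furthest, also beyond the scatter. Among the measured compounds shown here, no two measured compounds differ in a single place, so no measured step is available to anchor the next change.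

Compound 4 `CC(C)C(NC(=O)c1ccc(C#Cc2ccccc2)cc1)C(=O)NO` is the next compound, not yet measured. It differs from compound 2 as follows: isopropyl in place of methyl on a saturated chain carbon bound to an amide-type nitrogen and a carbonyl carbon.

For the measured compounds named here, with no measured step of the same kind, the expectation rests on compound 2 alone and on the nature of the change. A downward step in this assay is expected, a 2.4-fold lower number from compound 2 to compound 4 (0.38 log units; beyond the scatter), of a size that may or may not clear the scatter. Compound 4 is therefore estimated at 12000 nM, within a range from 4000 nM to 35000 nM.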

Compound 4, solubility: 7000 nM
Compound 4: the middle estimate sits 1.7-fold (0.23 log units) above what was measured, and the stated range covers the measured number.
By their numbers in this assay, from the lowest: compound 1; then compounds 3 and 4 (each within the scatter of the next); then compound 2.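

Working notes on the chain carbon bound to an amide-type nitrogen and a carbonyl carbon: in this assay, isopropyl in place of methyl gives the first single-place step in the series (a 4.1-fold lower number from compound 2 to compound 4 (0.62 log units; beyond the scatter)). Among the compounds shown here, the read-out therefore responds to the group at this position, and the response to this change is downward and modest, which the earlier compounds could not show. No supporting data bear on why the number moves.

A single step cannot show whether the change depends on the added carbons or on the branching, and a straight propyl chain at this position would separate the two. From the compounds shown here alone, it also remains open whether a group carrying an amine or a carboxylic acid at this position would move the number in the opposite direction from isopropyl.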